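Swapping an amine end-group on a second quinazoline core

A few compounds are considered here, and "the series" means these few. Any claim that something is new, unique, unknown or untested is made for them only; others in the source may bear on it.

Of the compounds shown here, three built on a shared core have been tested in a functional assay on A549 cells (Homo sapiens) for antiproliferative activity, read by MTT assay, with a stated time of 72 h; a higher number here means a weaker inhibitor, a lower number a stronger inhibitor. Compound 1, `CN(C)C/C=C/C(=O)Nc1cc2c(N3CCc4ccccc43)ncnc2cc1O[C@@H]1CCOC1`, gives 1090 nM. Compound 2, `CCN(CC)C/C=C/C(=O)Nc1cc2c(N3CCc4ccccc43)ncnc2cc1O[C@@H]1CCOC1`, gives 5220 nM, and compound 3, `CN(C)C/C=C/C(=O)Nc1cc2c(N3CCCc4ccccc43)ncnc2cc1O[C@@H]1CCOC1`, gives 2320 nM.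

Compound 1 and compound 2 differ only at the end of the chain: diethylamino in place of dimethylamino on a saturated chain carbon bound to a double-bonded chain carbon. That change produced a 4.8-fold higher number from compound 1 to compound 2 (0.68 log units; beyond the scatter). Compound 1 and compound 3 differ only in the core: 1,2,3,4-tetrahydroquinolin-1-yl in place of 2,3-dihydro-1H-indol-1-yl on an aromatic carbon. That change produced a 2.1-fold higher number from compound 1 to compound 3 (0.33 log units; beyond the scatter).

Compound 4, `CCN(CC)C/C=C/C(=O)Nc1cc2c(N3CCCc4ccccc43)ncnc2cc1O[C@@H]1CCOC1`, has not yet been measured. It carries the core of compound 3 together with the chain end of compound 2, so the change from compound 3 to compound 4 is diethylamino in place of dimethylamino on a saturated chain carbon bound to a double-bonded chain carbon. The place where this change occurs is described in the same words for both pairs, so it is the same change seen once before, only now on the other core.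

Among the compounds with values here, the one earlier instance, the step from compound 1 to compound 2, is the only guide available; whether the second core answers the same change in the same way cannot be checked against any measured pair. Compound 4 is therefore expected to show a 4.3-fold higher number from compound 3 to compound 4 (0.63 log units; beyond the scatter), resting on the step from compound 1 to compound 2. Compound 4 is estimated at 10000 nM, with a range from 4000 nM to 25000 nM in this assay.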

Compound 4, half-maximal inhibitory concentration: 5650 nM
Compound 4: middle estimate off by 1.8-fold (0.25 log units), on the high side, within the range that was stated.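

In this assay, putting diethylamino in place of dimethylamino on the second core gave a 2.4-fold higher number from compound 3 to compound 4 (0.39 log units; beyond the scatter), so the change pointed the same way on both cores, and the two steps do not differ by more than the scatter of two such steps allows: the same change on two cores in this assay, a 4.8-fold higher number (0.68 log units; beyond the scatter) from compound 1 to compound 2 and a 2.4-fold higher number (0.39 log units; beyond the scatter) from compound 3 to compound 4, 2.0-fold (0.29 log units) apart, within the scatter of two such steps The core swap, read with diethylamino at the chain end, gave a 1.1-fold higher number from compound 2 to compound 4 (0.03 log units; within the scatter), and this step also cannot be separated from its counterpart with dimethylamino at the chain end: the same change on two cores in this assay, a 2.1-fold higher number (0.33 log units; beyond the scatter) from compound 1 to compound 3 and a 1.1-fold higher number (0.03 log units; within the scatter) from compound 2 to compound 4, 2.0-fold (0.29 log units) apart, within the scatter of two such steps Together these four compounds suggest that, within this small set, the amine change and the core change can be read roughly independently, but two pairs per change are too few to make a rule, and they do not show that the step keeps a fixed size or why the numbers move.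

The compounds shown leave open how other amine end-groups, such as pyrrolidin-1-yl, piperidin-1-yl or morpholin-4-yl, would behave on these two cores, and whether they would follow the same pattern. They also leave open whether these steps would carry over to any other test, since every number here comes from this assay.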